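The source may report more compounds than this note shows. Statements on the series, on what has been measured and on what is new or still open speak of the compounds shown alone.

Compound 1 `CCC(=O)N1CCC(C(=O)N2N=CCC2c2ccccc2)CC1` gives > 2.75 h
Compound 2 `CC(C)(C)C(=O)N1N=CCC1c1cccnc1` gives > 1.5 h

In an ADME assay on microsomes (Homo sapiens) for metabolic stability (a lower number here means that the compound disappears faster, a higher number that the compound lasts longer), compound 1 gives > 2.75 h as a limit, not a number. Compound 2 also gives only a limit. Compound 3 `O=C(C1CCN(c2ccccc2)CC1)N1N=CCC1c1ccccc1` keeps the core of compound 1 but has phenyl in place of propanoyl on an amine nitrogen in a ring, and phenyl in place of propanoyl on an amine nitrogen in a ring counts that change in full. Among the measured compounds shown here, no measured pair shows a change of this kind, which leaves the expectation loose. The expected step of an at least 1.8-fold lower number from compound 1 to compound 3 (0.26 log units; that floor lies within the scatter) is downward in this assay, probably somewhat beyond the usual scatter. For compound 3 the estimated half-life is 1.5 h with an expected range from 0.5 h to 4 h in this assay.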

Compound 3, half-life: > 1.5 h
Compound 3 ended at the assay's limit; the forecaster's own chance of this, stated with the estimate: 35%; the middle value sits exactly at the limit.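

Among the compounds shown here, compound 1 and compound 3 both give only limits in this assay, and no step between them can be read. From the compounds shown here alone, the actual half-life of each compound, and whether phenyl in place of propanoyl changes it, stay open.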